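Removing a fluorine from a furan bis-amidine: hemolysis expected

The compounds below may be only part of what the source reports. "The series", "measured", "known", "first", "only" and "open" are said of these compounds alone.

Measured compounds:
- compound 1, `N=C(N)c1ccc(-c2ccc(-c3ccc(F)cc3)o2)o1`: "non-toxic" (no number reported)
- compound 2, `N=C(N)c1ccc(-c2ccc(-c3ccc(F)cc3)s2)s1`: "non-toxic" (no number reported)
- compound 3, `COc1ccc(-c2ccc(-c3ccc(C(=N)N)s3)s2)cc1`: 4%

In an ADME assay on cells (Erythrocyte, Homo sapiens) for activation, read by hemolysis, with a stated time of 30 min, tested at 0.625 mM (a lower number here means a weaker effect, a higher number a stronger effect of the compound at the concentration tested), compound 1 gives "non-toxic" (no number reported), a verdict rather than a number, so it cannot be placed on a scale. Compound 2 is reported in the same way, giving "non-toxic" (no number reported) in this assay. Only compound 3 carries a figure: in this assay compound 3 gives 4%, a small amount of red-cell breakage at the concentration tested. All three compounds therefore appear to leave erythrocytes largely intact.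

Compound 4, `N=C(N)c1ccc(-c2ccc(-c3ccccc3)o2)o1`, is not yet measured. It differs from compound 1 by one change: hydrogen in place of fluoro on an aromatic carbon. Going by the values given here, with no pair of measured compounds showing this kind of step, there is no measured guide to its effect. Given that every compound so far lies at the low end, the step in this assay is expected to be none beyond the scatter, in either direction.

Compound 4 is therefore expected to give about 4%, within a range of 0% to 15%.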

Compound 4, a percentage reported as activity, at one concentration (the size of the read-out at that concentration, not a potency): "non-toxic" (no number reported)
For compound 4 the study gives words and no number, so the estimate cannot be set against anything.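

In this assay compound 1 gives "non-toxic" (no number reported) and compound 4 gives "non-toxic" (no number reported) as well, so with verdicts instead of numbers no step can be read between them. On these data alone, whether hydrogen in place of fluoro changes red-cell breakage at all stays open. Nothing shown bears on this result.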